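Shortening the side chain in a cytotoxicity-limited series

This account rests on a few compounds, and the source may have more. Where it says the series, first, only, none or still open, it means among the compounds named here.

Compound 1 `CCOC(=O)NC(=O)NC1=CS(=O)(=O)O[C@@]12[C@@H](CO[Si](C)(C)C(C)(C)C)O[C@@H](n1cc(C)c(=O)n(C)c1=O)[C@@H]2O[Si](C)(C)C(C)(C)C` gives 16000 nM in a functional assay on HEL cells (Homo sapiens) for cytotoxicity, read by microscopy; a lower number here means that less compound is tolerated, a higher number that more compound is tolerated.
Compound 2 `Cc1cn([C@@H]2O[C@H](CO[Si](C)(C)C(C)(C)C)[C@@]3(OS(=O)(=O)C=C3NCC(=O)C(N)=O)[C@H]2O[Si](C)(C)C(C)(C)C)c(=O)n(C)c1=O` reaches only the assay limit of >= 16000 nM in this assay.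
Compound 3 `Cc1cn([C@@H]2O[C@H](CO[Si](C)(C)C(C)(C)C)[C@@]3(OS(=O)(=O)C=C3NC(=O)NC(=O)c3ccccc3)[C@H]2O[Si](C)(C)C(C)(C)C)c(=O)n(C)c1=O` likewise reaches only the assay limit of >= 80000 nM in this assay.

Compound 3 thus stands at a limit rather than at a number, and at the higher of the two limits seen (the limit of >= 80000 nM in this assay, at which 1 of the 3 values shown sits). Compound 4 `Cc1cn([C@@H]2O[C@H](CO[Si](C)(C)C(C)(C)C)[C@@]3(OS(=O)(=O)C=C3NCC(N)=O)[C@H]2O[Si](C)(C)C(C)(C)C)c(=O)n(C)c1=O` differs from it in one place: carbamoylmethyl in place of benzoylcarbamoyl on an amine nitrogen. Among the measured compounds shown here, two measured steps touch this spot. The step of an at least 5.0-fold higher number from compound 1 to compound 3 (0.69 log units; beyond the scatter) changed the chain at its carbonyl carbon. The step that the two limits leave unreadable from compound 2 to compound 3 swapped the whole group, as the present change does, but its two limits leave its size open. Compound 4 is therefore expected to sit near these limits, with wide uncertainty, the expected step being an at least 2.0-fold lower number from compound 3 to compound 4 (0.30 log units; that floor lies within the scatter). Compound 4 is estimated at 40000 nM, between 12000 nM and 120000 nM.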

Compound 4, minimum cytotoxic concentration: 16000 nM
Beside the measured number, compound 4's estimate is 2.5-fold (0.40 log units) above it; the measured number falls inside the stated range.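

Putting carbamoylmethyl in place of benzoylcarbamoyl on the amine nitrogen gives an at least 5.0-fold lower number from compound 3 to compound 4 (0.69 log units; beyond the scatter) in this assay. As far as these compounds go, its true size stays unknown because compound 3 stands at a limit: the limit of >= 80000 nM in this assay, at which 1 of the 4 values shown sits. The other readable step gives no change at the digits printed from compound 1 to compound 4 (within the scatter), so two quite different chains match here, and benzoylcarbamoyl stands apart from both.

The remaining step gives a number no higher from compound 2 to compound 4 (the limit leaves the size open), and its size cannot be read. From the compounds shown here alone, whether the phenyl ring drives the difference remains open, and a benzyl group or a free amine at this nitrogen would test that.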